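Replacing a fluoro with a methoxy in compound 3

The source may hold more compounds than are shown below. What is called first, only, known or untested is meant among the compounds shown, and "the series" means these compounds.

Compound 1 `O=S(=O)(CCC(F)(F)F)c1nc(-c2ccccc2)c(-c2ccccc2)[nH]1` gives > 75 mg/kg as a limit, not a number
Compound 2 `COc1ccc(-c2[nH]c(SC(F)(F)F)nc2-c2ccc(F)cc2)cc1` gives 2.7 mg/kg
Compound 3 `O=S(=O)(c1nc(-c2ccc(F)cc2)c(-c2ccc(F)cc2)[nH]1)C(F)(F)F` gives 0.016 mg/kg

All three were tested in a functional assay on the whole organism with Rattus norvegicus as the target (a higher number here means that more compound is needed for the effect, a lower number that less compound is needed), and a lower number is better here. Compound 3 has the lowest number shown, well beyond the scatter from compound 2.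

Compound 4 `COc1ccc(-c2[nH]c(S(=O)(=O)C(F)(F)F)nc2-c2ccc(F)cc2)cc1` has methoxy in place of fluoro on an aromatic carbon, para to a large group (methoxy in place of fluoro on an aromatic carbon). For the measured compounds named here, no measured pair shows this change alone. Compound 2 also carries a methoxy, but it differs from compound 3 in a second place too, so its gap gives only a loose ceiling. A moderate rise is expected, an estimated step (a 6.3-fold higher number from compound 3 to compound 4 (0.80 log units; beyond the scatter)) that more compound would be needed to cover. For compound 4 the expected value is 0.1 mg/kg with an estimated range from 0.02 mg/kg to 0.6 mg/kg (a rough judgement).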

Compound 4, dose for half-maximal effect: 1.4 mg/kg
Compound 4: middle estimate off by 14-fold (1.15 log units), on the low side; the measured number lies above the stated range.
By their numbers in this assay, from the lowest: compound 3; then compounds 4 and 2 (each within the scatter of the next). At a limit, above all of these: compound 1.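

Changing 4-fluorophenyl to 4-methoxyphenyl proves costly in this assay when the (trifluoromethyl)sulfonyl group is present (an 88-fold higher number from compound 3 to compound 4 (1.94 log units; beyond the scatter)), so this position is far from indifferent to the change. With the methoxy in place, exchanging (trifluoromethyl)sulfanyl for (trifluoromethyl)sulfonyl makes no clear difference (a 1.9-fold lower number from compound 2 to compound 4 (0.29 log units; within the scatter)). Nothing measured here accounts for the large step.

Going by these compounds, whether a chlorine, an amine or a carboxylic acid at this position would keep the need for compound as small as in compound 3 stays open. So does the effect of the same change on the other 4-fluorophenyl.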